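The source may report more compounds than this note shows. Statements on the series, on what has been measured and on what is new or still open speak of the compounds shown alone.

Compound 1 `N#Cc1ccc(/C=C/S(=O)(=O)Cc2ccc(Nc3ncnc4ccccc34)cc2)cc1` sits in a functional assay on U-251 cells (Homo sapiens) (a lower number here means a stronger inhibitor of growth, a higher number a weaker inhibitor of growth), at the limit of the assay, > 100000 nM. Compound 2 `O=S(=O)(/C=C/c1ccc(Cl)c(Cl)c1)Cc1ccc(Nc2ncnc3ccccc23)cc1` gives in this assay a number, 11000 nM. Compound 3 `O=S(=O)(/C=C/c1ccc(F)cc1F)Cc1ccc(Nc2ncnc3ccccc23)cc1` sits in this assay at the limit of the assay, > 100000 nM.

Among the compounds with values here, compound 2 therefore stands as the only compound of the three with a measured number in this assay; the other two values are limits, as the limit of > 100000 nM in this assay, at which 2 of the 3 values shown sit, states. The step to compound 4 `O=S(=O)(/C=C/c1ccc(O)cc1)Cc1ccc(Nc2ncnc3ccccc23)cc1` changes the same part of the shared core as the measured steps: 4-hydroxyphenyl in place of 3,4-dichlorophenyl on a double-bonded chain carbon bound to a double-bonded chain carbon. Within the data shown here, two measured steps bear on it. Among the measured compounds shown here, the step of an at least 9.0-fold lower number from compound 1 to compound 2 (0.95 log units; beyond the scatter) and the step of an at least 9.0-fold higher number from compound 2 to compound 3 (0.95 log units; beyond the scatter) show that exchanging the aryl group on the double-bonded chain carbon moves the number strongly in both directions, with compound 2 carrying the only aryl group that gives a number at all, while the step that the two limits leave unreadable from compound 1 to compound 3 cannot be read. For the 4-hydroxyphenyl group in compound 4 a step back toward the limit is expected, with the estimated step of a 5.5-fold higher number from compound 2 to compound 4 (0.74 log units; beyond the scatter) going to a higher number. Compound 4 is therefore estimated at 60000 nM, within 8000 nM to 200000 nM, with a fair chance that only a limit is reported.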

Compound 4, concentration for 50% growth inhibition: 300 nM
For compound 4 the middle estimate is 200-fold (2.30 log units) above the measured one; measured number below the stated range.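

In this assay, within the data shown here, 4-hydroxyphenyl in place of 3,4-dichlorophenyl on a double-bonded chain carbon bound to a double-bonded chain carbon gives a 37-fold lower number from compound 2 to compound 4 (1.56 log units; beyond the scatter), so this place can carry a group that brings the number well clear of the limit and far under the only number seen before. The gaps to the other two compounds are wider, an at least 330-fold lower number from compound 3 to compound 4 (2.52 log units; beyond the scatter) and an at least 330-fold lower number from compound 1 to compound 4 (2.52 log units; beyond the scatter), the last being hydroxy in place of cyano on an aromatic carbon, and both give only the smallest possible size of the step: the limit of > 100000 nM in this assay, at which 2 of the 4 values shown sit. The exchange from compound 2 to compound 4 also takes the aryl group from 0 hydrogen-bond donors to 1, but a single step cannot tie the drop in the number to that count.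

On these data alone, what a methoxy group, an amine or a carboxylic acid would give in place of the hydroxy group stays open. So does whether the low number of compound 4 holds with the hydroxy group kept and a chloro group added to the same ring.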